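This account rests on a few compounds, and the source may have more. Where it says the series, first, only, none or still open, it means among the compounds named here.

Measured compounds:
compound 1 `Cc1ccc(C(=O)O)cc1OCCCCOc1ccc(C(=O)CC2CCCC2)c(O)c1C` — 26.9%
compound 2 `CCC(=O)c1ccc(OCCCCOc2ccc(C(=O)O)cc2C)c(C)c1O` — 22.7%
compound 3 `CC(=O)c1ccc(OCCCCOc2ccc(C(=O)O)cc2C)c(C)c1O` — 25.4%

The three compounds were characterised in an assay on HEK293 cells for positive allosteric modulation of metabotropic glutamate receptor 3 (Rattus norvegicus), read by thallium flux, with a stated time of 2.5 min; a higher number here means a larger maximal response, a lower number a smaller maximal response. Compound 3 stands second highest of the three numbers, but its nearest neighbour, compound 1, lies only a little above it, and compound 2, the furthest, lies only a little below; both gaps fall within the scatter, so the three values are not distinguished from one another.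

The step under consideration leads from compound 3 to compound 4 `Cc1cc(C(=O)O)ccc1OCCCCOc1ccc(C(=O)CC2CCCC2)c(O)c1C`, which has not yet been measured in this assay. The change is cyclopentyl in place of hydrogen on a saturated chain carbon bound to a carbonyl carbon.

Within the data shown here, one measured step bears on this kind of alteration at the same place: a number 2.7 percentage points higher from compound 2 to compound 3 (within the scatter). That step, hydrogen in place of methyl on a saturated chain carbon bound to a carbonyl carbon, stayed within the scatter. Among the measured compounds shown here, compound 1 also carries a (cyclopentylmethyl)carbonyl group and gives 26.9%, close to the other two, although no single-change step from compound 1 to compound 4 is available here. Taken together, the data give no sign that altering this chain carbon moves the maximal response beyond the scatter.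

The account therefore expects for compound 4 a step of a number 0.6 percentage points higher from compound 3 to compound 4 (within the scatter), that is, no change beyond the scatter. For compound 4 the estimated value is 26%, with a range from 16% to 36%.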

Compound 4, largest response reached (reported as percent of maximum), in percent of the reference or control that the assay uses: 28.4%
Compound 4: the middle estimate sits 2.4 percentage points below what was measured; low and high end bracket the measured number.
By their numbers in this assay, from the lowest: compounds 2, 3, 1 and 4 (each within the scatter of the next).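

In this assay, the chain carbon bound to a carbonyl carbon now has a direct reading for its largest group: cyclopentyl in place of hydrogen gives a number 3 percentage points higher from compound 3 to compound 4 (within the scatter), and cyclopentyl in place of methyl gives a number 5.7 percentage points higher from compound 2 to compound 4 (within the scatter), so hydrogen, methyl and cyclopentyl at this place are not told apart, even though the entering group brings 5 heavy atoms and a five-membered ring. Compound 4 also opens a second comparison, elsewhere in the molecule: 4-carboxy-2-methylphenyl in place of 5-carboxy-2-methylphenyl on an oxygen on a saturated carbon gives a number 1.5 percentage points higher from compound 1 to compound 4 (within the scatter), so these two groups are not told apart either. Nothing available here offers an explanation for any of these readings.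

All the compounds shown keep a carboxylic acid, so it remains open whether an amide in its place would shift the maximal response beyond the scatter. On these data alone, it is also open whether a phenyl group or an amine on the chain carbon bound to a carbonyl carbon would do so.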